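Ethyl Replaces Hydrogen on the Amide-Type Nitrogen

The compounds below may be only part of what the source reports. "The series", "measured", "known", "first", "only" and "open" are said of these compounds alone.

Measured in a functional assay on A549 cells (Homo sapiens) for inhibition; a lower number here means a stronger inhibitor, a higher number a weaker inhibitor:
Compound 1, `CNC(=O)N1CC1C#N`: 22000 nM
Compound 2, `N#CC1CN1C(N)=O`: only the assay's limit, > 280000 nM

Compound 2 stands at the weak end of what has been measured; for compound 2 this assay gives a limit rather than a number. Swapping the methyl of compound 1 for hydrogen on the amide-type nitrogen produced an at least 12-fold higher number from compound 1 to compound 2 (1.10 log units; beyond the scatter), and the true size of that step may be even larger because of the limit of > 280000 nM in this assay, at which 1 of the 2 values shown sits.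

Compound 3, `CCNC(=O)N1CC1C#N`, moves the other way with a somewhat larger group: ethyl in place of hydrogen on an amide-type nitrogen. Among the measured compounds shown here, the only measured step bearing on this change is the methyl-to-hydrogen step, and it was large, so the reverse move from hydrogen to ethyl is expected to bring a large drop in this assay, back toward where compound 1 stands. The value for compound 3 is estimated at 15000 nM, with a range from 4000 nM to 70000 nM. That estimate means an expected step of an at least 18-fold lower number from compound 2 to compound 3 (1.27 log units; beyond the scatter).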

Compound 3, half-maximal inhibitory concentration: 18000 nM
Estimate against measurement, compound 3: 1.2-fold (0.08 log units) below, and the stated range covers the measured number.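

Putting ethyl on the amide-type nitrogen gives an at least 15-fold lower number from compound 2 to compound 3 (1.19 log units; beyond the scatter), so the gain over hydrogen at this place is not peculiar to methyl. Going from methyl to ethyl gives a 1.2-fold lower number from compound 1 to compound 3 (0.09 log units; within the scatter), which means that compound 1 and compound 3 cannot be told apart in this assay, and this place accepts the ethyl chain as well as the methyl. The full size of the step from hydrogen remains unknown, since compound 2 is known only as a limit: the limit of > 280000 nM in this assay, at which 1 of the 3 values shown sits.

On these data alone, how far this tolerance extends remains open: a longer chain such as butyl, a branched group such as tert-butyl, or a phenyl ring could behave differently. Also open, as far as these compounds go, is whether an amine or a carboxylic acid at the end of the chain would keep this level of inhibition.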